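A few compounds are considered here, and "the series" means these few. Any claim that something is new, unique, unknown or untested is made for them only; others in the source may bear on it.

Going by the values given here, compound 2 `COc1ccc(-c2cn3cc(C4=CCN(S(=O)(=O)C5CCCCC5)CC4)ccc3n2)cc1OC` gives 11100 nM in a functional assay on B16-F10 cells (Mus musculus) for antiproliferative activity, read by MTT assay, with a stated time of 48 h (on this read-out lower numbers stand for stronger inhibition and higher numbers for weaker inhibition), the top of the two numbers so far, yet the step of a 1.4-fold higher number from compound 1 to compound 2 (0.14 log units; within the scatter) lies within the scatter, so compound 1 `COc1ccc(-c2cn3cc(C4=CCN(C(=O)c5ccccc5C(F)(F)F)CC4)ccc3n2)cc1OC`, at 8110 nM, is not separated from it. Compound 3 `COc1ccc(-c2cn3cc(C4=CCN(S(=O)(=O)c5ccccc5)CC4)ccc3n2)cc1OC` differs from compound 2 by phenyl in place of cyclohexyl on a sulfonyl sulfur. Among the compounds with values here, no measured step covers this change directly; the one step available swapped the whole group on the ring amine nitrogen and stayed within the scatter, so no shift in this assay beyond the scatter is expected. The estimate for compound 3 is 10000 nM, range 4000 nM to 25000 nM, an expected step of a 1.1-fold lower number from compound 2 to compound 3 (0.05 log units; within the scatter).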

Compound 3, half-maximal inhibitory concentration: 13200 nM
For compound 3 the middle estimate is 1.3-fold (0.12 log units) below the measured one; low and high end bracket the measured number.
By their numbers in this assay, from the lowest: compounds 1, 2 and 3 (each within the scatter of the next).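

In this assay, phenyl in place of cyclohexyl on a sulfonyl sulfur gives a 1.2-fold higher number from compound 2 to compound 3 (0.08 log units; within the scatter), so at this place the aromatic and the non-aromatic six-membered carbon ring are not told apart. Replacing the whole group on the ring amine nitrogen gives a 1.6-fold higher number from compound 1 to compound 3 (0.21 log units; within the scatter), so phenylsulfonyl and (2-(trifluoromethyl)phenyl)carbonyl are not separated either. No supporting data bear on what lies behind these readings.

Still open, on these data alone, is whether an amine or a carboxylic acid on the phenyl ring of compound 3 would move the number beyond the scatter.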